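The source may hold more compounds than are shown below. What is called first, only, known or untested is meant among the compounds shown, and "the series" means these compounds.

In a functional assay on A20 cells (Mus musculus) for inhibition, with stated times of 1 h, 16 h and 24 h (on this read-out lower numbers stand for stronger inhibition and higher numbers for weaker inhibition), compound 1 `C[C@@H]1CN(C(=O)[C@@H]2C[C@H](S(=O)(=O)c3ccccc3)C[C@H]2C(=O)NC2(C#N)CC2)C[C@H](C)O1` gives 1 nM and compound 2 `N#CC1(NC(=O)[C@@H]2C[C@@H](S(=O)(=O)c3ccccc3)C[C@H]2C(=O)N2CC3CCC(C2)O3)CC1` gives 16 nM as the highest of the three numbers, while compound 3 `N#CC1(NC(=O)[C@@H]2C[C@@H](S(=O)(=O)c3ccccc3)C[C@H]2C(=O)N2CCCCC2)CC1` gives 5 nM and so stands in the middle. Compound 4 `N#CC1(NC(=O)[C@@H]2C[C@@H](S(=O)(=O)c3ccccc3)C[C@H]2C(=O)N2CCC(O)CC2)CC1` differs from compound 3 by hydroxy in place of hydrogen on a saturated ring carbon and so carries 4-hydroxypiperidin-1-yl in place of piperidin-1-yl on the carbonyl carbon.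

Among the compounds with values here, no measured step makes this exact change. The nearest evidence is the exchange of the group on the carbonyl carbon: a 5.0-fold higher number from compound 1 to compound 3 (0.70 log units; beyond the scatter) and a 3.2-fold lower number from compound 2 to compound 3 (0.51 log units; beyond the scatter) are both modest. Compound 1 and compound 2 both carry oxygen in that group, yet they fall on opposite sides of compound 3, so oxygen there sets no single direction. A step no larger than those two is expected, most likely small and leaning towards a higher number in this assay overall.

The expected step is a 1.6-fold higher number from compound 3 to compound 4 (0.20 log units; within the scatter) on this estimate. For compound 4 the estimated value is 8 nM with an expected range from 3 nM to 25 nM on present evidence.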

Compound 4, half-maximal inhibitory concentration: 371 nM
For compound 4 the middle estimate is 46-fold (1.67 log units) below the measured one, and the stated range ends below it.
By their numbers in this assay, from the lowest: compound 1; then compound 3; then compound 2; then compound 4.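

Notes on the series: in this assay, hydroxy in place of hydrogen on a saturated ring carbon, three ring bonds from the ring nitrogen, gives a 74-fold higher number from compound 3 to compound 4 (1.87 log units; beyond the scatter), so this one added oxygen on the piperidin-1-yl group is far from neutral. The same group also stands well apart from the two other oxygen-bearing groups on the carbonyl carbon, with a 23-fold higher number from compound 2 to compound 4 (1.37 log units; beyond the scatter) and a 370-fold higher number from compound 1 to compound 4 (2.57 log units; beyond the scatter), so oxygen in compound 1 and compound 2 is compatible with far lower numbers than hydroxy at this place. Nothing measured here accounts for the size of these steps.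

Going by these compounds, whether any group at this ring carbon raises the number, or hydroxy specifically, remains open; methoxy, fluoro or an amine there would separate the two. Also open, on these data alone, is how hydroxy behaves on another carbon of the same ring.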